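Nitrile series: tert-butyl to ((3-chlorobenzyl)oxy)methyl

The compounds below may be only part of what the source reports. "The series", "measured", "known", "first", "only" and "open" are said of these compounds alone.

Compound 1 `CC(C)C[C@H](NC(=O)N1CCOCC1)C(=O)NCC#N` gives 124 nM in an assay for inhibition of cathepsin S (Homo sapiens); a lower number here means a stronger inhibitor, a higher number a weaker inhibitor.
Compound 2 `CC(C)C[C@H](NC(=O)N1CCOCC1)C(=O)N[C@H](C#N)C(C)(C)C` gives 107000 nM in this assay.

For the measured compounds named here, compound 2 has the highest number of the two measured; the only measured step, an 860-fold higher number from compound 1 to compound 2 (2.94 log units; beyond the scatter), is large. Compound 3 `CC(C)C[C@H](NC(=O)N1CCOCC1)C(=O)N[C@H](C#N)COCc1cccc(Cl)c1` differs from compound 2 by ((3-chlorobenzyl)oxy)methyl in place of tert-butyl on a saturated chain carbon bound to an amide-type nitrogen and a triple-bonded carbon. Going by the values given here, no measured step compares these two groups directly; the one step bearing on this position, an 860-fold higher number from compound 1 to compound 2 (2.94 log units; beyond the scatter), shows that a group in place of hydrogen there raised the number sharply, so a group other than tert-butyl may or may not do the same. For compound 3 a lower number than compound 2 is expected, a 54-fold lower number from compound 2 to compound 3 (1.73 log units; beyond the scatter), with wide uncertainty. Compound 3 is estimated at 2000 nM, range 100 nM to 40000 nM.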

Compound 3, half-maximal inhibitory concentration: 9 nM
For compound 3 the middle estimate is 220-fold (2.35 log units) above the measured one, and the stated range ends above it.
By their numbers in this assay, from the lowest: compound 3; then compound 1; then compound 2.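

In this assay ((3-chlorobenzyl)oxy)methyl in place of tert-butyl gives a 12000-fold lower number from compound 2 to compound 3 (4.08 log units; beyond the scatter) on this carbon, and the same group in place of hydrogen gives a 14-fold lower number from compound 1 to compound 3 (1.14 log units; beyond the scatter) in the other direction from the unsubstituted nitrile. The sharp rise seen with tert-butyl therefore does not hold for every group at this place, and a group here can lower the number below that of hydrogen. Nothing shown accounts for the difference between the two groups.

Which part of the new group matters remains open: the ether oxygen, the aromatic ring or the chlorine. A benzyloxymethyl group without chlorine, or a longer hydrocarbon chain in place of the ether, would begin to separate these.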